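The source may report more compounds than this note shows. Statements on the series, on what has been measured and on what is new or still open speak of the compounds shown alone.

Among the compounds with values here, in an assay on isolated protein for inhibition of protein kinase C delta type (Homo sapiens), read by TR-FRET, with a stated time of 2 h (on this read-out higher numbers stand for weaker inhibition and lower numbers for stronger inhibition), the three measured members sit close to the ceiling of the read-out. Compound 1 `CO[C@H]1CC[C@H](CNc2cc(NCc3cnccc3C(F)(F)F)ncc2C#N)CC1` gives > 10000 nM, which is a limit of the assay rather than a number. Compound 2 `N#Cc1cnc(NCc2cnccc2C(F)(F)F)cc1NC1CCOCC1` gives 9800 nM. Compound 3 `N#Cc1cnc(NCc2cnccc2C(F)(F)F)cc1NCCC1CCOCC1` gives > 10000 nM, again only a limit. The steps of an at least 1.0-fold lower number from compound 1 to compound 2 (0.00 log units; that floor lies within the scatter) and an at least 1.0-fold higher number from compound 2 to compound 3 (0.00 log units; that floor lies within the scatter) stay at their floors, and a step that the two limits leave unreadable from compound 1 to compound 3 cannot be read because both ends sit at the limit of > 10000 nM in this assay, at which 2 of the 3 values shown sit. Within the data shown here, compound 3 therefore stands at the limit, with compound 2 the only member of the three that shows a number in this assay.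

Compound 4 `CC1(C)C[C@@H](Nc2cc(NCc3cnccc3C(F)(F)F)ncc2C#N)CC[C@H]1O` differs from compound 3 by 4-hydroxy-3,3-dimethylcyclohexyl in place of 2-(oxan-4-yl)ethyl on a nitrogen on an aromatic ring. The steps from compound 1 and from compound 2 to compound 3 touch the same nitrogen on the aromatic ring and were either at their floors or unreadable, so no step beyond the scatter is expected in this assay, the estimated step being a number no higher from compound 3 to compound 4 (the limit leaves the size open). Compound 4 is expected to give 10000 nM in this assay, between 3000 nM and 30000 nM.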

Compound 4, half-maximal inhibitory concentration: 2400 nM
Beside the measured number, compound 4's estimate is 4.2-fold (0.62 log units) above it; measured number below the stated range.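

Within the data shown here, at the nitrogen on the aromatic ring, 4-hydroxy-3,3-dimethylcyclohexyl gives the first step in this assay with a number at both ends that lies beyond the scatter: a 4.1-fold lower number from compound 2 to compound 4 (0.61 log units; beyond the scatter). Among these compounds, the same replacement gives an at least 4.1-fold lower number from compound 3 to compound 4 (0.61 log units; beyond the scatter) and an at least 4.1-fold lower number from compound 1 to compound 4 (0.61 log units; beyond the scatter), so this place on the shared core does respond to its substituent, whereas the earlier steps there stayed at their floors or could not be read. The last two steps are only floors because compound 1 and compound 3 each sit at a limit of the assay: the limit of > 10000 nM in this assay, at which 2 of the 4 values shown sit.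

Compound 4 brings in a carbon-only ring, a hydrogen-bond donor and two defined stereocentres together, and the compounds shown do not separate these features. Going by these compounds, whether plain cyclohexyl, or 4-hydroxycyclohexyl without the two methyl groups, would keep the step remains open.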